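A few compounds are considered here, and "the series" means these few. Any claim that something is new, unique, unknown or untested is made for them only; others in the source may bear on it.

Compound 1 `Cc1ccc(Nc2cc(NC(=O)Nc3c(Cl)cccc3Cl)ncn2)cc1F` stands highest of the three compounds measured in a functional assay on PC-9 cells (Homo sapiens) for inhibition, read by MTT assay, with a stated time of 48 h, tested at 10 uM (on this read-out lower numbers stand for less inhibition and higher numbers for more inhibition at the one concentration tested (going by the name of the read-out)), where compound 1 gives 92%. Compound 2 `COc1cc(NC(=O)Nc2cc(Nc3ccc(F)c(Cl)c3)ncn2)cc(OC)c1` gives 77.5% in this assay, and compound 3 `COc1cc(NC(=O)Nc2cc(Nc3ccc(C)c(F)c3)ncn2)cc(OC)c1` gives 77.5%, each lying below compound 1 by a margin beyond the scatter; the two lower values lie within the scatter of each other. Within the data shown here, the only step between measured compounds that differ in one place is the one between compound 2 and compound 3, where 3-fluoro-4-methylphenyl replaces 3-chloro-4-fluorophenyl on a nitrogen on an aromatic ring, and there no change at the digits printed from compound 2 to compound 3 (within the scatter).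

Compound 4 `COc1ccc(Nc2cc(NC(=O)Nc3c(Cl)cccc3Cl)ncn2)cc1C` differs from compound 1 in the same region: 4-methoxy-3-methylphenyl in place of 3-fluoro-4-methylphenyl on a nitrogen on an aromatic ring. The step from compound 2 to compound 3 bears on this change, since it too exchanges the aryl group on that nitrogen while the rest of the shared core stays fixed, and it produced nothing beyond the scatter. Among the measured compounds shown here, the incoming 4-methoxy-3-methylphenyl carries one hydrogen-bond acceptor that none of the measured compounds carries at this position, so no measured step covers that part of the change. The expectation is therefore a step of a number 7 percentage points lower from compound 1 to compound 4 (within the scatter) in this assay, no larger than the scatter. Compound 4 is accordingly estimated to give 85% in this assay, within a range from 70% to 95%.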

Compound 4, a percentage reported as inhibition, at one concentration (the size of the read-out at that concentration, not a potency): 80.1%
Beside the measured number, compound 4's estimate is 4.9 percentage points above it; measured number inside the range.
By their numbers in this assay, from the lowest: compounds 2, 3 and 4 (each within the scatter of the next); then compound 1.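

The change to 4-methoxy-3-methylphenyl in place of 3-fluoro-4-methylphenyl on a nitrogen on an aromatic ring gave a number 11.9 percentage points lower from compound 1 to compound 4 (beyond the scatter) in this assay, so exchanging the aryl group at this place can shift the read-out, which the earlier exchange, with no change at the digits printed from compound 2 to compound 3 (within the scatter), had not shown. This step is modest and comes from a single concentration, so it describes a size of inhibition rather than a potency, and it bundles several differences: fluorine leaves, oxygen enters and a hydrogen-bond acceptor appears where the leaving group has none. Nothing available explains the step or assigns it to any one of these differences.

The compounds shown leave open whether the methoxy group, the loss of fluorine or the altered arrangement of the methyl group carries the step, and whether the same exchange would give a similar step on the core of compound 2. They also leave open how this position would respond to a longer chain such as ethoxy, or to an amine or a carboxylic acid on the aryl ring.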